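The compounds below may be only part of what the source reports. "The series", "measured", "known", "first", "only" and "open" are said of these compounds alone.

Compound 1 `Fc1ccc(Nc2nc(-c3cccc(F)c3)nc3ccc(F)cc23)cc1` is the starting point, and in a functional assay on HT29-AK cells (Homo sapiens) for cytotoxicity, read by MTT assay, with a stated time of 48 h (on this read-out higher numbers stand for weaker inhibition and lower numbers for stronger inhibition), compound 1 gives > 50000 nM, which is a limit of the assay rather than a measured number. Two compounds with the same core stand next to it. Compound 2 `Fc1cccc(-c2nc(Nc3ccc(Cl)cc3)c3cc(F)ccc3n2)c1` gives 40300 nM in this assay, and the step of an at least 1.2-fold lower number from compound 1 to compound 2 (0.09 log units; that floor lies within the scatter) rests on chloro in place of fluoro on an aromatic carbon. Compound 3 `Oc1ccccc1Nc1nc(-c2cccc(F)c2)nc2ccc(F)cc12` gives > 50000 nM in this assay, again a limit. The step that the two limits leave unreadable from compound 1 to compound 3 is therefore open, and the step of an at least 1.2-fold higher number from compound 2 to compound 3 (0.09 log units; that floor lies within the scatter) is read only as a floor. Compound 1 thus stands at the weak end of this read-out, where the limit of > 50000 nM in this assay, at which 2 of the 3 values shown sit, shows most of these values resting.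

The compound still to be measured is compound 4 `Nc1cccc(Nc2nc(-c3cccc(F)c3)nc3ccc(F)cc23)c1`. It differs from compound 1 by 3-aminophenyl in place of 4-fluorophenyl on a nitrogen on an aromatic ring. The two steps made at the same nitrogen, from compound 1 to compound 3 and from compound 2 to compound 3, bear on this change, and neither carries a compound away from the weak end in this assay. Compound 4 is expected to show the step of a number no higher from compound 1 to compound 4 (the limit leaves the size open), meaning no move beyond the scatter. Compound 4 is accordingly estimated at 50000 nM, with an expected range from 15000 nM to 50000 nM.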

Compound 4, half-maximal inhibitory concentration: > 50000 nM
Compound 4 ended at the assay's limit; the forecaster's own chance of this, stated with the estimate: 70%; the middle value sits exactly at the limit.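

For the compounds shown here, at the nitrogen on the aromatic ring, 3-aminophenyl, which unlike 4-fluorophenyl counts a hydrogen-bond donor and acceptor, joins 2-hydroxyphenyl in leaving the compound at the limit of this assay, so a second, different replacement of 4-fluorophenyl at this place also gives no measurable value: the limit of > 50000 nM in this assay, at which 3 of the 4 values shown sit. The comparison with compound 2, the only compound here with a measured number rather than a limit, gives an at least 1.2-fold higher number from compound 2 to compound 4 (0.09 log units; that floor lies within the scatter), so 3-aminophenyl and 4-chlorophenyl are not separated beyond the scatter. The steps to compound 4 from compound 1 and from compound 3 cannot be read, with a limit at each end.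

The compounds shown leave open how far compound 1, compound 3 and compound 4 each lie past the limit, and so whether these groups differ from one another at all. They also leave open whether a carboxylic acid on the phenyl ring, or a longer chain carrying an amine in place of that ring on the same nitrogen, would bring a value clearly down from the limit.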